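Short acyl group on the ring nitrogen: compound 4

A few compounds are considered here, and "the series" means these few. Any claim that something is new, unique, unknown or untested is made for them only; others in the source may bear on it.

Compound 3 `O=C(Nc1ccccc1C(F)(F)F)C1CCc2ccccc2N1` carries a bare hydrogen on the ring nitrogen of the shared core. In a functional assay on ACHN cells (Homo sapiens) for cytotoxicity, read by sulforhodamine B assay, with a stated time of 72 h (a lower number here means a stronger inhibitor of growth, a higher number a weaker inhibitor of growth), compound 3 gives 57600 nM, the highest of the two plain numbers seen here; its nearest neighbour is compound 2 `CCCCCCCCC(=O)N1c2ccccc2CCC1C(=O)Nc1ccccc1C(F)(F)F`, which gives 8330 nM. The third member, compound 1 `CCCC(=O)N1c2ccccc2CCC1C(=O)Nc1ccccc1C(F)(F)F`, reports only a limit in this assay, namely > 70000 nM. That reading is the limit of > 70000 nM in this assay, at which 1 of the 3 values shown sits, so no true number exists for compound 1.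

Compound 4 `CCC(=O)N1c2ccccc2CCC1C(=O)Nc1ccccc1C(F)(F)F` differs from compound 3 by propanoyl in place of hydrogen on a nitrogen on an aromatic ring in a ring. Among the compounds with values here, two measured steps bear on this change: a 6.9-fold higher number from compound 2 to compound 3 (0.84 log units; beyond the scatter), and an at least 1.2-fold lower number from compound 1 to compound 3 (0.08 log units; that floor lies within the scatter), in which a chain only one carbon longer than the one entering here leaves the number within the scatter of compound 3. The short chain of compound 4 is therefore expected to change little, and the expected step is a 1.1-fold higher number from compound 3 to compound 4 (0.05 log units; within the scatter), with no movement beyond the scatter. Compound 4 is estimated at 65000 nM, within a range from 25000 nM to 200000 nM, and the assay may well report it only as a limit.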

Compound 4, concentration for 50% growth inhibition: > 80000 nM
Compound 4: a limit, no number; the forecaster's own chance of this, stated with the estimate: 50%; middle value at least 1.2-fold (0.09 log units) from the limit.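

In this assay compound 4 reports only a limit, not a true number: the limit of > 80000 nM in this assay, at which 1 of the 4 values shown sits. Putting propanoyl on the ring nitrogen gives an at least 1.3-fold higher number from compound 3 to compound 4 (0.14 log units; that floor lies within the scatter), so this short acyl group shows no gain in growth inhibition over the bare hydrogen. The long chain stands clearly apart, with an at least 9.6-fold higher number from compound 2 to compound 4 (0.98 log units; beyond the scatter), while the step between compound 1 and compound 4 cannot be read, since both are limits.

The compounds shown leave open how long the acyl chain must be before the number starts to fall, which a hexanoyl group could help to show, and whether a chain longer than that of compound 2, such as dodecanoyl, would lower it further. They also leave open what an amine or a carboxylic acid at the end of the chain would do.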